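Amine-linked aryl swap on the shared core

The source may report more compounds than this note shows. Statements on the series, on what has been measured and on what is new or still open speak of the compounds shown alone.

Three compounds of the shared core have numbers in a functional assay on OVCAR-5 cells (Homo sapiens) for inhibition, read by sulforhodamine B assay, with a stated time of 48 h; on this read-out lower numbers stand for stronger inhibition of growth and higher numbers for weaker inhibition of growth. Among the measured compounds shown here, compound 1 `Nc1cc(N)c2nc(-c3ccccc3)c(Oc3ccc(Cl)c(Cl)c3)nc2c1` gives 58900 nM and compound 3 `Nc1cc(N)c2nc(-c3ccccc3)c(Sc3ccc(F)cc3)nc2c1` gives 45700 nM; the step of a 1.3-fold lower number from compound 1 to compound 3 (0.11 log units; within the scatter) is the only one-place change measured so far. Compound 2 `Nc1cc(N)c2nc(-c3ccccc3)c(NCc3ccc(Cl)c(Cl)c3)nc2c1` gives 40700 nM; its gaps to compound 3 and to compound 1 both lie within the scatter, so none of the three is set apart. Compound 4 `COc1ccc(CNc2nc3cc(N)cc(N)c3nc2-c2ccccc2)cc1OC` differs from compound 2 by 3,4-dimethoxyphenyl in place of 3,4-dichlorophenyl on a saturated chain carbon bound to a nitrogen on an aromatic ring. For the measured compounds named here, no measured step changes the group on this saturated chain carbon, and the one aryl swap measured, a 1.3-fold lower number from compound 1 to compound 3 (0.11 log units; within the scatter), lay within the scatter. In this assay compound 4 is therefore expected to move no further than the scatter, a 1.0-fold higher number from compound 2 to compound 4 (0.01 log units; within the scatter). Compound 4 is expected to give 42000 nM, in the range 18000 nM to 95000 nM.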

Compound 4, concentration for total growth inhibition: 41700 nM
Beside the measured number, compound 4's estimate is 1.0-fold (0.00 log units) above it; the range from low to high includes it.
By their numbers in this assay, from the lowest: compounds 2, 4, 3 and 1 (each within the scatter of the next).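

In this assay, among the compounds shown here, the first measured step on a saturated chain carbon bound to a nitrogen on an aromatic ring is a 1.0-fold higher number from compound 2 to compound 4 (0.01 log units; within the scatter) and it stays within the scatter. At this place, 3,4-dimethoxyphenyl with its hydrogen-bond acceptors and 3,4-dichlorophenyl with none cannot be told apart on this read-out. No available evidence bears on this result.

Going by these compounds, whether a longer chain at this place, or a carboxylic acid or an amine on the aryl ring, would move the number beyond the scatter remains open.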